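Working notes on a two-compound series and compound 3

The source may hold more compounds than are shown below. What is called first, only, known or untested is meant among the compounds shown, and "the series" means these compounds.

Measured so far:
compound 1 `CC(C)Cn1c(CN2CCN(C(=O)C3CC3)CC2)nc2ccccc21`; in an assay on isolated protein for inhibition of aldehyde dehydrogenase 1A1 (Homo sapiens), read by spectrophotometry, tested at 10 uM (a lower number here means less inhibition, a higher number more inhibition at the concentration tested (going by the name of the read-out)), compound 1 gives 13.1%
compound 2 `Cc1ccccc1Cn1c(CN2CCN(C(=O)C3CC3)CC2)nc2ccccc21`; in this assay compound 2 gives 29.1%

Within the data shown here, compound 2 stands highest of the two numbers; its nearest neighbour is compound 1, and the only measured step runs a number 16 percentage points higher from compound 1 to compound 2 (beyond the scatter), a modest change that reaches beyond the scatter.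

Compound 3 `O=C(C1CC1)N1CCN(Cc2nc3ccccc3n2Cc2cccc(Cl)c2)CC1` differs from compound 2 by 3-chlorophenyl in place of 2-methylphenyl on a saturated chain carbon bound to an aromatic nitrogen. Among the measured compounds shown here, the one step measured so far exchanges an isopropyl for a 2-methylphenyl on that same saturated chain carbon bound to an aromatic nitrogen; it shows that the number is higher with a six-membered aromatic ring there, but it gives no guide to exchanging one such ring for another. For the measured compounds named here, no other step bears on the change. The expectation for compound 3 in this assay is therefore a number close to that of compound 2, with no step beyond the scatter expected, a number 0.9 percentage points higher from compound 2 to compound 3 (within the scatter). Compound 3 is estimated at 30%, in a range from 14% to 50%.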

Compound 3, a percentage reported as inhibition, at one concentration (the size of the read-out at that concentration, not a potency): 71.6%
Compound 3: middle estimate off by 41.6 percentage points, on the low side; the measured number lies above the stated range.
By their numbers in this assay, from the lowest: compound 1; then compound 2; then compound 3.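

In this assay, exchanging one six-membered aromatic ring for another on the saturated chain carbon bound to an aromatic nitrogen is far from neutral: 3-chlorophenyl in place of 2-methylphenyl gives a number 42.5 percentage points higher from compound 2 to compound 3 (beyond the scatter) and is a larger step than the one from isopropyl to 2-methylphenyl. Set against isopropyl, 3-chlorophenyl gives a number 58.5 percentage points higher from compound 1 to compound 3 (beyond the scatter) so the number at this position depends on which aromatic ring is present, not only on there being one. Nothing available explains the difference between the two rings.

The step from compound 2 to compound 3 changes both the ring substituent and its place on the ring, and the compounds shown do not separate the two. Also open, from the compounds shown here alone, is how an unsubstituted phenyl, or a phenyl carrying an amine or a carboxylic acid, would read here.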